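Swapping Dimethoxyphenyl Patterns in Amide Inhibitors

A few compounds are considered here, and "the series" means these few. Any claim that something is new, unique, unknown or untested is made for them only; others in the source may bear on it.

Measured compounds:
compound 1 `COc1ccc(NC(=O)c2cc3ccc(OCc4ccccc4)cc3oc2=O)cc1OC`: 4390 nM
compound 2 `COc1cc(NC(=O)c2cc3ccc(OCc4ccccc4)cc3oc2=O)cc(OC)c1`: 3360 nM
compound 3 `COc1ccc(NC(=O)c2cc3ccc(OCc4ccc(F)cc4)cc3oc2=O)cc1OC`: 2870 nM

These three values come from an in vitro assay on BTI-TN-5B1-4 cells for inhibition of Amine oxidase [flavin-containing] B (Homo sapiens), read by fluorescence; a higher number here means a weaker inhibitor, a lower number a stronger inhibitor. Compound 3 differs from compound 1 by fluoro in place of hydrogen on an aromatic carbon, and this change gave a 1.5-fold lower number from compound 1 to compound 3 (0.18 log units; within the scatter). Compound 2 differs from compound 1 by 3,5-dimethoxyphenyl in place of 3,4-dimethoxyphenyl on an amide-type nitrogen, a change that gave a 1.3-fold lower number from compound 1 to compound 2 (0.12 log units; within the scatter). Compound 4 `COc1cc(NC(=O)c2cc3ccc(OCc4ccc(F)cc4)cc3oc2=O)cc(OC)c1` has not been measured; it differs from compound 3 by 3,5-dimethoxyphenyl in place of 3,4-dimethoxyphenyl on an amide-type nitrogen, the same change seen between compound 1 and compound 2, at the same place. Compound 4 is therefore expected to show a step of about a 1.3-fold lower number from compound 3 to compound 4 (0.12 log units; within the scatter) in this assay, because the same change earlier gave a 1.3-fold lower number from compound 1 to compound 2 (0.12 log units; within the scatter). On that basis compound 4 is estimated at 2200 nM, with the expected range running from 1100 nM to 4400 nM.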

Compound 4, half-maximal inhibitory concentration: 21600 nM
Compound 4: the middle estimate sits 9.8-fold (0.99 log units) below what was measured; the measured number lies above the stated range.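

In this assay, the change from 3,4-dimethoxyphenyl to 3,5-dimethoxyphenyl on the amide-type nitrogen did not carry over to the fluoro-bearing core, where it gave a 7.5-fold higher number from compound 3 to compound 4 (0.88 log units; beyond the scatter): the same change on two cores in this assay, a 1.3-fold lower number (0.12 log units; within the scatter) from compound 1 to compound 2 and a 7.5-fold higher number (0.88 log units; beyond the scatter) from compound 3 to compound 4, 9.8-fold (0.99 log units) apart, beyond the scatter of two such steps. Read the other way round, the fluoro change gave a 6.4-fold higher number from compound 2 to compound 4 (0.81 log units; beyond the scatter), so it too depended on its partner group: the same change on two cores in this assay, a 1.5-fold lower number (0.18 log units; within the scatter) from compound 1 to compound 3 and a 6.4-fold higher number (0.81 log units; beyond the scatter) from compound 2 to compound 4, 9.8-fold (0.99 log units) apart, beyond the scatter of two such steps. This shows that the two changes do not simply add across these four compounds, but it does not show why, nor how either change would behave on any other core.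

The compounds shown leave open whether a chloro or a methyl group in place of the fluoro would give the same break. They also leave open how a 3,4,5-trimethoxyphenyl on the amide-type nitrogen would behave.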